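Chain extension at the aryl ether of the triazole series

A few compounds are considered here, and "the series" means these few. Any claim that something is new, unique, unknown or untested is made for them only; others in the source may bear on it.

Compound 2 `CCCOc1ccc(-n2cnnc2CC)cc1` is the starting point of this step. In a functional assay on the whole organism (strain C57B/6) with Mus musculus as the target, in the maximal electroshock model (a lower number here means that less compound is needed, a higher number that more compound is needed for the effect), compound 2 gives only a limit, > 100 mg/kg, and no number. That limit is the one at which one of the two values in the series sits (the limit of > 100 mg/kg in this assay, at which 1 of the 2 values shown sits). The measured companion is compound 1 `CCc1nncn1-c1ccc(OCc2ccc(Cl)cc2)cc1`, which in this assay gives 19.7 mg/kg. Among the compounds with values here, the one measured step, an at least 5.0-fold higher number from compound 1 to compound 2 (0.70 log units; beyond the scatter), shows that exchanging the 4-chlorophenyl group for ethyl on the saturated chain carbon bound to the ring oxygen costs potency beyond the scatter.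

Compound 3 `CCCCCCOc1ccc(-n2cnnc2CC)cc1` differs from compound 2 by propyl in place of hydrogen on a saturated chain carbon, three bonds along the chain from an oxygen on an aromatic ring. The step from compound 1 to compound 2 bears on this only loosely: it shows that a larger group on the chain went with the lower number, while no chain of this length has been measured. Because of an at least 5.0-fold higher number from compound 1 to compound 2 (0.70 log units; beyond the scatter) a modest move toward a lower number is expected for compound 3, an at least 1.6-fold lower number from compound 2 to compound 3 (0.22 log units; that floor lies within the scatter), though the change differs in kind. Compound 3 is therefore estimated at 60 mg/kg, with a range from 20 mg/kg to 150 mg/kg in this assay.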

Compound 3, dose for half-maximal effect: 13.2 mg/kg
For compound 3 the middle estimate is 4.5-fold (0.66 log units) above the measured one; measured number below the stated range.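

In this assay, propyl in place of hydrogen on the saturated chain carbon, three bonds along the chain from the oxygen on the aromatic ring, gives an at least 7.5-fold lower number from compound 2 to compound 3 (0.87 log units; beyond the scatter), so a plain open chain at this position is enough for a step of this size. The 4-chlorophenyl group of compound 1 is therefore not needed for potency in this series: a 1.5-fold lower number from compound 1 to compound 3 (0.17 log units; within the scatter), and compound 1 and compound 3 cannot be told apart in this assay. The first of these steps has only a floor, as compound 2 stands at a limit of the assay and not at a number: the limit of > 100 mg/kg in this assay, at which 1 of the 3 values shown sits.

From the compounds shown here alone, with only the propyl and hexyl ethers in hand, the shape of the chain-length trend stays open: a butyl or pentyl chain would show where along the chain the change sets in, and a longer chain such as octyl whether it continues. Also open, going by these compounds, is how the hexyl chain would read in this assay with an amine or a hydroxyl group at its end, or with a branch along it.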